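A larger group on the sulfur-bound chain of the shared core

This account rests on a few compounds, and the source may have more. Where it says the series, first, only, none or still open, it means among the compounds named here.

Compound 1, `CCSc1nnc(-c2cc(OC)c(OC)c(OC)c2)n1-c1ccc(OC)cc1`: in a functional assay on HT-29 cells (Homo sapiens) for inhibition, read by MTT assay, with a stated time of 48 h (on this read-out lower numbers stand for stronger inhibition and higher numbers for weaker inhibition), compound 1 gives > 60000 nM, which is a limit of the assay and not a number.
Compound 2, `CCOC(=O)CSc1nnc(-c2cc(OC)c(OC)c(OC)c2)n1-c1ccc(OC)cc1`: in this assay compound 2 gives > 60000 nM, again a limit of the assay.
Compound 3, `CCSc1nnc(-c2cc(OC)c(OC)c(OC)c2)n1-c1ccc(N(C)C)cc1`: in this assay compound 3 gives > 60000 nM, also a limit of the assay.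

Compound 3 therefore stands at the same limit as the other two measured compounds; the three values together give (the limit of > 60000 nM in this assay, at which 3 of the 3 values shown sit), and nothing separates them. The step that the two limits leave unreadable from compound 1 to compound 2 changed the same place that is changed here, and the step that the two limits leave unreadable from compound 1 to compound 3 changed the aryl group that compound 3 carries into compound 4, but both steps lie between limits and their size cannot be read.

Compound 4, `COc1cc(-c2nnc(SCC(=O)c3ccc4ccccc4c3)n2-c2ccc(N(C)C)cc2)cc(OC)c1OC`, differs from compound 3 by (naphthalen-2-yl)carbonyl in place of methyl on a saturated chain carbon bound to a sulfur. The measured steps give no direction for this change, so the expectation is anchored only at the limit where compound 3 sits. The step from compound 3 to compound 4 is expected to be an at least 2.0-fold lower number from compound 3 to compound 4 (0.30 log units; that floor lies within the scatter) in this assay, with a wide range. Compound 4 is estimated to give 30000 nM in this assay, between 5000 nM and 100000 nM.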

Compound 4, half-maximal inhibitory concentration: > 60000 nM
Compound 4 was reported as a limit (the forecaster's own chance of this, stated with the estimate: 45%); middle value at least 2.0-fold (0.30 log units) from the limit.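

Compound 3 and compound 4 both stand at a limit of the assay, so the step from compound 3 to compound 4 cannot be read: the limit of > 60000 nM in this assay, at which 4 of the 4 values shown sit. The compounds shown leave open whether any change on the shared core would give a measurable number at all.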